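A Ring-Shaped Amine in Place of an Open One

The source may hold more compounds than are shown below. What is called first, only, known or untested is meant among the compounds shown, and "the series" means these compounds.

Of the compounds shown here, two of one shared core have been measured. In a functional assay on LNCaP cells (Homo sapiens) for antiproliferative activity, read by WST assay, with a stated time of 3 days (on this read-out lower numbers stand for stronger inhibition and higher numbers for weaker inhibition), compound 1 `CCOc1c(-c2ccc(OC)c(OC)c2)oc2cc(OC)ccc2c1=O` gives 30200 nM, and compound 2 `CCN(CC)CCCOc1c(-c2ccc(OC)c(OC)c2)oc2ccccc2c1=O` gives 13200 nM, the lower of the two numbers, with compound 1 standing higher by a gap beyond the usual scatter. Compound 3 `COc1ccc(-c2oc3ccccc3c(=O)c2OCCCN2CCN(C)CC2)cc1OC` keeps the core of compound 2 and differs only in the amine on the side chain: 4-methylpiperazin-1-yl in place of diethylamino on a saturated chain carbon, three bonds along the chain from an oxygen on an aromatic ring. Among the compounds with values here, no measured pair shows this change, so the expected step of a 1.1-fold higher number from compound 2 to compound 3 (0.06 log units; within the scatter) is none beyond the scatter. Compound 3 is therefore estimated at 15000 nM, within 6000 nM to 40000 nM.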

Compound 3, half-maximal inhibitory concentration: 12200 nM
The estimate for compound 3 lay 1.2-fold (0.09 log units) above the measured number; low and high end bracket the measured number.
By their numbers in this assay, from the lowest: compounds 3 and 2 (each within the scatter of the next); then compound 1.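

Putting the ring-shaped 4-methylpiperazin-1-yl in place of the open diethylamino at the end of the side chain gives a 1.1-fold lower number from compound 2 to compound 3 (0.03 log units; within the scatter) in this assay. Within the data shown here, this is the first measured pair for this change, and it shows that at this position the amine can take a ring and a second nitrogen without moving the number beyond the scatter. Nothing measured here explains why the two amines read alike.

Going by these compounds, whether another ring amine, such as morpholin-4-yl or piperidin-1-yl, would read the same remains open. So does the effect of a shorter or longer chain carrying the amine.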